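From Pyridinyl to Dichlorophenyl in a Potassium Channel Activator Series

A few compounds are considered here, and "the series" means these few. Any claim that something is new, unique, unknown or untested is made for them only; others in the source may bear on it.

Measured compounds:
compound 1 `CC1(c2cc(NC(=O)Cn3nnc(-c4ccccc4)n3)n(C3CCCCC3)n2)CC1` — > 10000 nM
compound 2 `Cc1cc(NC(=O)Cn2nnc(-c3cccnc3)n2)n(C2CCCCC2)n1` — 1930 nM

Among the measured compounds shown here, in an assay on HEK293 cells for activation of Kir3.1/Kir3.2 (Homo sapiens), read by thallium flux (on this read-out lower numbers stand for an effect already at smaller amounts and higher numbers for an effect only at larger amounts of compound), compound 2 gives 1930 nM, the only numerical value in this set. The result for compound 1 is a limit of the assay rather than a number (the limit of > 10000 nM in this assay, at which 1 of the 2 values shown sits). Compound 3 `Cc1cc(NC(=O)Cn2nnc(-c3cc(Cl)cc(Cl)c3)n2)n(C2CCCCC2)n1` has not yet been measured; it differs from compound 2 by 3,5-dichlorophenyl in place of pyridin-3-yl on an aromatic carbon. For the measured compounds named here, no step between measured compounds exists to guide the size of this change, so the step expected in this assay is a 1.6-fold lower number from compound 2 to compound 3 (0.21 log units; within the scatter), a modest shift toward lower concentrations that may not exceed the usual scatter. Compound 3 is therefore estimated at 1200 nM, with a range from 300 nM to 6000 nM.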

Compound 3, half-maximal effective concentration: 980 nM
The estimate for compound 3 lay 1.2-fold (0.09 log units) above the measured number, within the range that was stated.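

In this assay, putting 3,5-dichlorophenyl in place of pyridin-3-yl on this aromatic carbon gives a 2.0-fold lower number from compound 2 to compound 3 (0.29 log units; within the scatter). The position therefore tolerates a ring of carbon only, bearing two chlorine atoms and no hydrogen-bond acceptor, with no change beyond the scatter. Nothing shown here explains this result.

Compound 1 differs from compound 3 in more than one place, so it cannot isolate the effect of either group. From the compounds shown here alone, how this position responds to a ring carrying an amine or a carboxylic acid remains open.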